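Notes: 4-methylphenyl to 4-methoxyphenyl in the series

This account rests on a few compounds, and the source may have more. Where it says the series, first, only, none or still open, it means among the compounds named here.

In an ADME assay on HaCaT cells (Homo sapiens) for inhibition, read by sulforhodamine B assay, with a stated time of 48 h (a lower number here means a stronger inhibitor of growth, a higher number a weaker inhibitor of growth), compound 1 `CC(C)(C)NCc1c(C(=O)O)nn(-c2ccc(Cl)cc2)c1-c1ccc(Cl)cc1` gives 87500 nM and compound 2 `CC(C)(C)NCc1c(C(=O)O)nn(-c2ccc(Cl)cc2)c1-c1ccccc1` gives 175000 nM.

Compound 3 `Cc1ccc(-c2c(CNC(C)(C)C)c(C(=O)O)nn2-c2ccc(Cl)cc2)cc1` gives > 629000 nM, which is a limit of the assay and not a number.

Compound 4 `COc1ccc(-c2c(CNC(C)(C)C)c(C(=O)O)nn2-c2ccc(Cl)cc2)cc1` differs from compound 3 by methoxy in place of methyl on an aromatic carbon.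

Going by the values given here, no measured step has methoxy entering. The closest guides are the changes at this same place. These are a 2.0-fold higher number from compound 1 to compound 2 (0.30 log units; within the scatter), an at least 7.1-fold higher number from compound 1 to compound 3 (0.85 log units; beyond the scatter) and an at least 3.5-fold higher number from compound 2 to compound 3 (0.55 log units; beyond the scatter). Among the compounds with values here, only the steps to methyl show a change beyond the scatter, and both of those end at a limit, so their true size is open.

A modest step to a lower number in this assay is therefore expected, though with little confidence in its direction. The expected step is an at least 1.7-fold lower number from compound 3 to compound 4 (0.25 log units; that floor lies within the scatter).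

For compound 4 the estimate is 350000 nM, with an expected range of 120000 nM to 800000 nM.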

Compound 4, concentration for 50% growth inhibition: 121000 nM
Compound 4: middle estimate off by 2.9-fold (0.46 log units), on the high side, within the range that was stated.
By their numbers in this assay, from the lowest: compounds 1, 4 and 2 (each within the scatter of the next). At a limit, above all of these: compound 3.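

In this assay, the change from 4-methylphenyl to 4-methoxyphenyl gives an at least 5.1-fold lower number from compound 3 to compound 4 (0.71 log units; beyond the scatter), so the weak reading with methyl at this position does not carry over to methoxy, the other group here that adds carbon. Methoxy cannot be told apart from hydrogen, a 1.4-fold lower number from compound 2 to compound 4 (0.16 log units; within the scatter), or from chloro, a 1.4-fold higher number from compound 1 to compound 4 (0.14 log units; within the scatter), which leaves methyl as the only one of the four groups set apart at this position. Compound 3 stands at a limit and not at a number: the limit of > 629000 nM in this assay, at which 1 of the 4 values shown sits.

Going by these compounds, how far compound 3 truly lies from the other three compounds stays open. Also open, on these data alone, is whether an amine or a longer chain such as ethyl at this position would read with compounds 1, 2 and 4 or with compound 3.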